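Fluorophenyl isomers in the series: working notes

The compounds below may be only part of what the source reports. "The series", "measured", "known", "first", "only" and "open" are said of these compounds alone.

- compound 1 `NC(=O)[C@@H]1[C@H](Nc2nc(Nc3cccc(C(=O)N4CCCC4)c3)ncc2-c2ccccc2F)[C@H]2C=C[C@@H]1C2`: 130 nM
- compound 2 `NC(=O)[C@@H]1[C@H](Nc2nc(Nc3cccc(C(=O)N4CCCC4)c3)ncc2-c2cccc(F)c2)[C@H]2C=C[C@@H]1C2`: 870 nM

In a functional assay on THP-1 cells (Homo sapiens) for inhibition, read by ELISA, with stated times of 1 h and 18 h (on this read-out lower numbers stand for stronger inhibition and higher numbers for weaker inhibition), compound 2 stands highest of the two measured compounds, at 870 nM. Compound 3 `NC(=O)[C@@H]1[C@H](Nc2nc(Nc3cccc(C(=O)N4CCCC4)c3)ncc2-c2ccc(F)cc2)[C@H]2C=C[C@@H]1C2` is its isomer, with 4-fluorophenyl in place of 3-fluorophenyl on an aromatic carbon. For the measured compounds named here, only one measured step bears on this change, a modest one between fluorophenyl isomers: a 6.7-fold higher number from compound 1 to compound 2 (0.83 log units; beyond the scatter). That single step gives no direction for the new change, so no step beyond the scatter is expected. The estimated step is a 1.5-fold lower number from compound 2 to compound 3 (0.16 log units; within the scatter). The estimate for compound 3 is 600 nM, with an expected range of 180 nM to 1500 nM.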

Compound 3, half-maximal inhibitory concentration: 460 nM
Compound 3: middle estimate off by 1.3-fold (0.12 log units), on the high side; the measured number falls inside the stated range.
By their numbers in this assay, from the lowest: compound 1; then compounds 3 and 2 (each within the scatter of the next).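

The 4-fluorophenyl and 3-fluorophenyl isomers are not separated on this read-out: a 1.9-fold lower number from compound 2 to compound 3 (0.28 log units; within the scatter). The 4-fluorophenyl isomer still stands apart from the 2-fluorophenyl isomer, with a 3.5-fold higher number from compound 1 to compound 3 (0.55 log units; beyond the scatter), so compound 1 alone has steps to both other isomers beyond the scatter. No measurement at hand accounts for this difference.

From the compounds shown here alone, whether the lower number of compound 1 is specific to fluorine remains open. A chlorine or a methoxy group on the same phenyl ring, or a phenyl ring with no substituent, would test this.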